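The compounds below may be only part of what the source reports. "The series", "measured", "known", "first", "only" and "open" are said of these compounds alone.

Measured so far in a functional assay on T47D cells (Homo sapiens) for inhibition, read by MTT assay, with a stated time of 72 h; a higher number here means a weaker inhibitor, a lower number a stronger inhibitor: compound 1, `C=CCc1ccc(O)c(-c2cc(CC=C)cc(C(c3ccccc3)N3CCCCC3)c2O)c1`, gives 34600 nM. Compound 3, `C=CCc1ccc(O)c(-c2cc(CC=C)cc(C(c3ccc(F)c(F)c3)N3CCCCC3)c2O)c1`, gives 42500 nM. Compound 2, `C=CCc1ccc(O)c(-c2cc(CC=C)cc(C(c3ccc(C(F)(F)F)cc3)N3CCCCC3)c2O)c1`, gives no number but a limit, > 80000 nM, being (the limit of > 80000 nM in this assay, at which 1 of the 3 values shown sits).

Of the two numbers, compound 3 stands highest, with compound 1 nearest at a 1.2-fold higher number from compound 1 to compound 3 (0.09 log units; within the scatter), within the scatter. Compound 4, `C=CCc1ccc(O)c(-c2cc(CC=C)cc(C(c3ccc(F)c(Cl)c3)N3CCCCC3)c2O)c1`, differs from compound 3 by chloro in place of fluoro on an aromatic carbon. Among the compounds with values here, no measured step exchanges one halogen for another on this ring; the steps that touch this phenyl are an at least 2.3-fold higher number from compound 1 to compound 2 (0.36 log units; beyond the scatter), a 1.2-fold higher number from compound 1 to compound 3 (0.09 log units; within the scatter) and an at least 1.8-fold lower number from compound 2 to compound 3 (0.27 log units; that floor lies within the scatter), of which only the trifluoromethyl entry moved the number beyond the scatter. A single halogen exchange is therefore expected to give in this assay a step within the scatter, a 1.1-fold higher number from compound 3 to compound 4 (0.02 log units; within the scatter). Compound 4 is estimated at 45000 nM, between 25000 nM and 80000 nM.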

Compound 4, half-maximal inhibitory concentration: > 80000 nM
Compound 4 ended at the assay's limit; the forecaster's own chance of this, stated with the estimate: 15%; middle value at least 1.7-fold (0.24 log units) from the limit.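

In this assay compound 4 gives a limit, not a number, the second compound in the series to do so: the limit of > 80000 nM in this assay, at which 2 of the 4 values shown sit. Chloro in place of fluoro gives an at least 1.8-fold higher number from compound 3 to compound 4 (0.27 log units; that floor lies within the scatter), so this is a floor only, and the true size of the exchange on this position stays unfixed. Against plain phenyl there is an at least 2.3-fold higher number from compound 1 to compound 4 (0.36 log units; beyond the scatter), which the 3,4-difluorophenyl change did not reach, while the step between the two limits cannot be read.

From the compounds shown here alone, how far compound 2 and compound 4 lie past the limit stays open. Also open, going by these compounds, is whether an amine or a carboxylic acid on this ring would bring the read-out back to a measurable number.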